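The source may hold more compounds than are shown below. What is called first, only, known or untested is meant among the compounds shown, and "the series" means these compounds.

Measured in a functional assay on MCF7 cells (Homo sapiens) for inhibition, read by MTT assay, with a stated time of 72 h; on this read-out higher numbers stand for weaker inhibition and lower numbers for stronger inhibition:
- compound 1 `Cc1cc(Nc2cc(-c3ccccc3)[nH]n2)n2nc(SCCCc3ccccc3)nc2n1`: 3900 nM
- compound 2 `C#CCSc1nc2nc(C)cc(Nc3cc(-c4ccccc4)[nH]n3)n2n1`: 21800 nM
- compound 3 `C=CCSc1nc2nc(C)cc(Nc3cc(-c4ccccc4)[nH]n3)n2n1`: > 50000 nM (a limit of the assay, not a number)

Compound 3 has no number on this scale, only a limit. That places it at the limit of > 50000 nM in this assay, at which 1 of the 3 values shown sits.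

Compound 4 `Cc1cc(Nc2cc(-c3ccccc3)[nH]n2)n2nc(SCc3csc4ccccc34)nc2n1` carries 1-benzothiophen-3-yl in place of vinyl on a saturated chain carbon bound to a sulfur.

The closest evidence comes from the group at this same place. The series shows an at least 12-fold higher number from compound 1 to compound 3 (1.10 log units; beyond the scatter), which is large, and it replaces phenethyl with vinyl. Compound 4 makes a change in the opposite direction, from vinyl to a larger group containing aromatic rings. The other two steps are smaller: a 5.6-fold higher number from compound 1 to compound 2 (0.75 log units; beyond the scatter) and an at least 2.2-fold higher number from compound 2 to compound 3 (0.36 log units; beyond the scatter). Among these three compounds, vinyl gives the highest reading and phenethyl the lowest.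

Read in reverse, the step to compound 1 suggests a large move towards a lower number, meaning stronger inhibition, in this assay. Benzothiophene is not phenethyl, however, so this transfer is uncertain. The expected step is an at least 8.3-fold lower number from compound 3 to compound 4 (0.92 log units; beyond the scatter). For compound 4 the estimated value is 6000 nM, with an expected range from 1500 nM to 25000 nM.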

Compound 4, half-maximal inhibitory concentration: 3470 nM
The estimate for compound 4 lay 1.7-fold (0.24 log units) above the measured number; the measured number falls inside the stated range.
By their numbers in this assay, from the lowest: compounds 4 and 1 (each within the scatter of the next); then compound 2. At a limit, above all of these: compound 3.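

In this assay compound 3 has no number, only a limit of the assay: the limit of > 50000 nM in this assay, at which 1 of the 4 values shown sits.

Set against that limit, 1-benzothiophen-3-yl in place of vinyl on a saturated chain carbon bound to a sulfur gives an at least 14-fold lower number from compound 3 to compound 4 (1.15 log units; beyond the scatter), and in place of ethynyl it gives a 6.3-fold lower number from compound 2 to compound 4 (0.80 log units; beyond the scatter). Within the data shown here, until now only phenethyl had given a reading this low at this position, but 1-benzothiophen-3-yl stands level with it, with a 1.1-fold lower number from compound 1 to compound 4 (0.05 log units; within the scatter), so among the four compounds the two groups that carry an aromatic ring both read lower than vinyl and ethynyl, and no compound goes against this.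

The compounds shown leave open whether the aromatic ring itself matters or only the larger size of the group, a question that a longer saturated chain with no ring, such as hexyl, would address. On these data alone, how an amine or a carboxylic acid at this place would read also stays open, as does whether any group can take the reading clearly lower than that of compound 4, at 3470 nM.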